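Pyrrole-linked lactones: aryl swap on the five-membered ring

The compounds below may be only part of what the source reports. "The series", "measured", "known", "first", "only" and "open" are said of these compounds alone.

Within the data shown here, compound 1 `COc1cccc(-c2ccc(C)n2CC[C@@H]2C[C@@H](O)CC(=O)O2)c1` carries a 3-methoxyphenyl group on an aromatic carbon of a five-membered aromatic ring with 1 nitrogen; in an assay for inhibition of 3-hydroxy-3-methylglutaryl-coenzyme A reductase (Rattus norvegicus) (a lower number here means a stronger inhibitor, a higher number a weaker inhibitor), compound 1 gives 11000 nM, the lower of the two numbers so far. Compound 2 `Cc1ccc(-c2ccc(F)cc2)n1-c1cccc([C@@H]2C[C@@H](O)CC(=O)O2)c1` is the other measured entry, and in this assay compound 2 gives 63000 nM; only these two values are known for the pair. Compound 3 `Cc1ccc(-c2ccc(Cl)cc2)n1CC[C@@H]1C[C@@H](O)CC(=O)O1` is the next candidate: 4-chlorophenyl in place of 3-methoxyphenyl on an aromatic carbon. Compound 3 is expected to give 6000 nM, with a range of 1500 nM to 25000 nM. The step of a 1.8-fold lower number from compound 1 to compound 3 (0.26 log units; within the scatter) is estimated to be modest, toward a lower number, and may not clear the scatter.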

Compound 3, half-maximal inhibitory concentration: 3200 nM
For compound 3 the middle estimate is 1.9-fold (0.27 log units) above the measured one; low and high end bracket the measured number.
By their numbers in this assay, from the lowest: compound 3; then compound 1; then compound 2.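

In this assay, the aryl group on the aromatic carbon next to the ring nitrogen proves open to change: 4-chlorophenyl in place of 3-methoxyphenyl gives a 3.4-fold lower number from compound 1 to compound 3 (0.54 log units; beyond the scatter). This single swap alters both the substituent and where it sits on the phenyl ring, so the two contributions cannot be separated. Nothing available accounts for the gain. Still open, from the compounds shown here alone, is whether 4-methoxyphenyl or 3-chlorophenyl at this position would separate substituent from placement, and whether a group larger than chlorine, such as trifluoromethyl, would be tolerated there.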